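Phenyl to pyridin-2-yl on the tetrazole of compound 1

This account rests on a few compounds, and the source may have more. Where it says the series, first, only, none or still open, it means among the compounds named here.

Measured:
compound 1, `Cc1cc(NC(=O)Cn2nnc(-c3ccccc3)n2)n(C2CCCCC2)n1`, 92%
compound 2, `O=C(Cn1nnc(-c2ccccc2)n1)Nc1cc(C2(C(F)(F)F)CC2)nn1C1CCCCC1`, no number (reported as not active)

Within the data shown here, in an assay on HEK293 cells for activation of Kir3.1/Kir3.2 (Homo sapiens), read by thallium flux (a higher number here means a larger maximal response, a lower number a smaller maximal response), compound 1 gives 92%, the only number in the set. Among the measured compounds shown here, compound 2 gives "not active" (no number reported), without a figure, so no step between measured compounds can be stated. Compound 3, `Cc1cc(NC(=O)Cn2nnc(-c3ccccn3)n2)n(C2CCCCC2)n1`, differs from compound 1 by pyridin-2-yl in place of phenyl on an aromatic carbon. For the measured compounds named here, no measured pair tells how this change acts; the expectation is a step within the scatter or a small loss. Compound 3 is expected at 80%, range 40% to 105%, a step of a number 12 percentage points lower from compound 1 to compound 3 (beyond the scatter) that is expected to stay near the scatter.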

Compound 3, largest response reached (Emax), in percent of the reference or control that the assay uses: 81%
Compound 3: the middle estimate sits 1 percentage points below what was measured, within the range that was stated.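

In this assay, among these compounds, pyridin-2-yl in place of phenyl on the aromatic carbon of the five-membered ring with 4 nitrogen gives a number 11 percentage points lower from compound 1 to compound 3 (beyond the scatter) as the first measured step at this place. The added ring nitrogen, with its hydrogen-bond acceptor, therefore costs only a modest part of the maximal response. Nothing at hand accounts for the step.

Whether the outcome depends on where the ring nitrogen sits remains open, as pyridin-3-yl and pyridin-4-yl are not among the compounds shown. Also open, as far as these compounds go, is how a non-aromatic group such as morpholine would fare here.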